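From Chlorophenyl to Dimethoxyphenyl: Little Change Expected

This account rests on a few compounds, and the source may have more. Where it says the series, first, only, none or still open, it means among the compounds named here.

Three measured compounds share one core and differ in the aryl group on the amine side. In a functional assay on HPAC cells (Homo sapiens) for inhibition, read by MTT assay, with a stated time of 72 h (a lower number here means a stronger inhibitor of growth, a higher number a weaker inhibitor of growth), compound 1 `O=S(=O)(NCCCNCc1cccc2ccccc12)c1cc(C(F)(F)F)cc(C(F)(F)F)c1` gives 2400 nM. In this assay compound 2 `O=S(=O)(NCCCCNCc1ccc(Br)cc1)c1cc(C(F)(F)F)cc(C(F)(F)F)c1` gives 2000 nM. Compound 3 `O=S(=O)(NCCCNCc1ccc(Cl)cc1)c1cc(C(F)(F)F)cc(C(F)(F)F)c1` gives 2800 nM in this assay, the highest of the three numbers, though a 1.2-fold higher number from compound 1 to compound 3 (0.07 log units; within the scatter) and a 1.4-fold higher number from compound 2 to compound 3 (0.15 log units; within the scatter) are both within the scatter. Compound 4 `COc1ccc(CNCCCNS(=O)(=O)c2cc(C(F)(F)F)cc(C(F)(F)F)c2)cc1OC` differs from compound 3 by 3,4-dimethoxyphenyl in place of 4-chlorophenyl on a saturated chain carbon bound to an amine nitrogen. Among the compounds with values here, the only step at the same place, a 1.2-fold higher number from compound 1 to compound 3 (0.07 log units; within the scatter), changed the aryl group without moving the number beyond the scatter, and a 1.4-fold higher number from compound 2 to compound 3 (0.15 log units; within the scatter) was equally small. No step beyond the scatter is therefore expected for compound 4, so no change at the digits printed from compound 3 to compound 4 (within the scatter) is the estimated change. Compound 4 is expected to give 2800 nM, within 1200 nM to 6500 nM.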

Compound 4, concentration for 50% growth inhibition: 3500 nM
Compound 4: middle estimate off by 1.3-fold (0.10 log units), on the low side, within the range that was stated.
By their numbers in this assay, from the lowest: compounds 2, 1, 3 and 4 (each within the scatter of the next).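

In this assay, 3,4-dimethoxyphenyl, with its 2 hydrogen-bond acceptors, replaces 4-chlorophenyl (a 1.3-fold higher number from compound 3 to compound 4 (0.10 log units; within the scatter)) and naphthalen-1-yl (a 1.5-fold higher number from compound 1 to compound 4 (0.16 log units; within the scatter)), and both steps stay within the scatter. The position on a saturated chain carbon bound to an amine nitrogen thus accepts a larger aryl group bearing oxygen with no step beyond the scatter. Nothing available explains this result.

On these data alone, it remains open whether any group at this place would move the number beyond the scatter, such as a cyclohexyl ring or a phenyl ring bearing a carboxylic acid.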